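Oxamate series: acid in place of the ester

The source may hold more compounds than are shown below. What is called first, only, known or untested is meant among the compounds shown, and "the series" means these compounds.

For the measured compounds named here, compound 1 `CCOCCOC(=O)C(=O)Nc1nc(-c2cc(C)no2)cs1` gives 0.04 mg/kg in a functional assay on the whole organism with Rattus norvegicus as the target (on this read-out lower numbers stand for an effect already at smaller amounts and higher numbers for an effect only at larger amounts of compound), the lowest of the two numbers measured so far. Going by the values given here, compound 2 `CCOCCOC(=O)C(=O)Nc1nc(-c2cc(C(=O)OCC)no2)cs1` gives 0.08 mg/kg in this assay; the only measured step, a 2.0-fold higher number from compound 1 to compound 2 (0.30 log units; within the scatter), concerns a different part of the molecule than the ester. Compound 3 `Cc1cc(-c2csc(NC(=O)C(=O)O)n2)on1` differs from compound 1 by hydrogen in place of 2-ethoxyethyl on an oxygen next to a carbonyl group. Among the compounds with values here, no measured step touches this group, so nothing indicates a shift in this assay beyond the scatter in either direction. Compound 3 is therefore expected at 0.05 mg/kg in this assay, within 0.015 mg/kg to 0.2 mg/kg. This estimate means a 1.3-fold higher number from compound 1 to compound 3 (0.10 log units; within the scatter), with a wide range.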

Compound 3, dose for half-maximal effect: 0.3 mg/kg
The estimate for compound 3 lay 6.0-fold (0.78 log units) below the measured number; measured number above the stated range.
By their numbers in this assay, from the lowest: compounds 1 and 2 (each within the scatter of the next); then compound 3.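

For the compounds shown here, the ester position is sensitive in a way the earlier compounds could not show: in this assay the change from 2-ethoxyethoxy to hydroxy gives a step beyond the scatter (a 7.5-fold higher number from compound 1 to compound 3 (0.88 log units; beyond the scatter)). Going by these compounds alone, the only earlier step lay in another part of the molecule and within the scatter (a 2.0-fold higher number from compound 1 to compound 2 (0.30 log units; within the scatter)). No measurement bearing on the reason for this shift is available.

Open, from the compounds shown here alone, is whether a methyl ester or a primary amide at this carbonyl would read closer to compound 1 or to compound 3. Also open, going by these compounds, is whether the same change gives a similar step on compound 2.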